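From pyridin-2-yl to 1H-pyrazol-3-yl on a carbonyl carbon

A few compounds are considered here, and "the series" means these few. Any claim that something is new, unique, unknown or untested is made for them only; others in the source may bear on it.

In a physicochemical assay for lipophilicity, read by HPLC, measured as chromatographic lipophilicity, at pH 7.4 (a higher number here means a more lipophilic compound, a lower number a more polar compound), compound 1 (`O=C(c1ccccc1)N1CCC(C(=O)N2N=CCC2c2ccccc2)CC1`) gives 4.4, compound 2 (`CN1CCC(C(=O)N2N=CCC2c2ccccc2)CC1`) gives 1.1 and compound 3 (`O=C(c1ccccn1)N1CCC(C(=O)N2N=CCC2c2ccccc2)CC1`) gives 3.1, the second highest of the three numbers. Compound 4 (`O=C(c1cc[nH]n1)N1CCC(C(=O)N2N=CCC2c2ccccc2)CC1`) carries 1H-pyrazol-3-yl in place of pyridin-2-yl on a carbonyl carbon. The closest measured change, at the same place, is the large a number 1.30 log units lower from compound 1 to compound 3 (beyond the scatter), where pyridin-2-yl replaced phenyl. The large a number 3.30 log units lower from compound 1 to compound 2 (beyond the scatter) and a number 2.00 log units higher from compound 2 to compound 3 (beyond the scatter) exchange the whole group on the amine nitrogen, so they bear less directly. A smaller, downward move in this assay is expected, with an estimated a number 0.40 log units lower from compound 3 to compound 4 (beyond the scatter). Compound 4 is estimated at 2.7, with an expected range of 2.2 to 3.2.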

Compound 4, distribution coefficient: 2.4
For compound 4 the middle estimate is 0.30 log units above the measured one, and the stated range covers the measured number.
By their numbers in this assay, from the lowest: compound 2; then compound 4; then compound 3; then compound 1.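

In this assay, 1H-pyrazol-3-yl on the carbonyl carbon brings a number 0.70 log units lower from compound 3 to compound 4 (beyond the scatter) and, measured against phenyl, a number 2.00 log units lower from compound 1 to compound 4 (beyond the scatter), so this position still responds when one aromatic ring replaces another and a hydrogen-bond donor enters. The group keeps its distance from methyl on the amine nitrogen, with a number 1.30 log units higher from compound 2 to compound 4 (beyond the scatter). Nothing available accounts for these steps. The change alters ring size, hetero atoms and donor count together, and the compounds shown do not separate them. As far as these compounds go, how an amine or a carboxylic acid would read on this carbonyl carbon remains open.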